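A few compounds are considered here, and "the series" means these few. Any claim that something is new, unique, unknown or untested is made for them only; others in the source may bear on it.

Measured compounds:
compound 1, `COc1ccc(C2=NN(C3=NC(=O)/C(=C4\C(=O)Nc5ccc(Br)cc54)S3)C(c3ccc(OC)cc3)C2)cc1`, 200 nM
compound 2, `COc1ccc(C2CC(c3ccc4ccccc4c3)=NN2C2=NC(=O)/C(=C3\C(=O)Nc4ccc(Br)cc43)S2)cc1`, 46 nM
compound 3, `COc1ccc(C2=NN(C3=NC(=O)/C(=C4\C(=O)Nc5ccccc54)S3)C(c3ccc(Cl)cc3)C2)cc1`, 77500 nM

In a functional assay on cells (Cancer cell lines, Homo sapiens) for cytotoxicity, read by sulforhodamine B assay, with a stated time of 48 h (on this read-out lower numbers stand for stronger inhibition of growth and higher numbers for weaker inhibition of growth), compound 1 gives 200 nM and compound 2 gives 46 nM. The step between them, (naphthalen-2-yl in place of 4-methoxyphenyl on a carbon with a double bond to nitrogen), produced a 4.3-fold lower number from compound 1 to compound 2 (0.64 log units; beyond the scatter). Compound 3 gives 77500 nM in this assay, the highest of the three numbers; the difference between its core and the core of compound 1 is not broken down here.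

Compound 4, `O=C1N=C(N2N=C(c3ccc4ccccc4c3)CC2c2ccc(Cl)cc2)S/C1=C1/C(=O)Nc2ccccc21`, has not yet been measured. It differs from compound 3 by naphthalen-2-yl in place of 4-methoxyphenyl on a carbon with a double bond to nitrogen, the same kind of change as that from compound 1 to compound 2, though the surroundings are not identical: in compound 3 the ring atom two ring bonds away bears a 4-chlorophenyl group (7 heavy atoms), whereas in compound 1 it bears a 4-methoxyphenyl group (8 heavy atoms). If the change behaves as before, a step of about a 4.3-fold lower number from compound 3 to compound 4 (0.63 log units; beyond the scatter) is expected, resting on the single earlier example a 4.3-fold lower number from compound 1 to compound 2 (0.64 log units; beyond the scatter) and on compound 3 starting from 77500 nM. Compound 4 is accordingly estimated at 18000 nM in this assay, between 4000 nM and 80000 nM, with wide uncertainty because the core of compound 3 sits so far from compound 1 at 200 nM.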

Compound 4, concentration for 50% growth inhibition: 8800 nM
Compound 4: the middle estimate sits 2.0-fold (0.31 log units) above what was measured, and the stated range covers the measured number.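

In this assay, naphthalen-2-yl in place of 4-methoxyphenyl gave an 8.8-fold lower number from compound 3 to compound 4 (0.94 log units; beyond the scatter), so the same change lowered the number on both cores, and the two steps agree in size: the same change on two cores in this assay, a 4.3-fold lower number (0.64 log units; beyond the scatter) from compound 1 to compound 2 and an 8.8-fold lower number (0.94 log units; beyond the scatter) from compound 3 to compound 4, 2.0-fold (0.31 log units) apart, within the scatter of two such steps

This shows that the step carried over to a second core in this series, even though the numbers on that core lie much higher. It does not show that the change would hold on any further core, as two pairs are a small basis, nor does it show what the naphthalen-2-yl group does to produce the step.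

The compounds shown leave open whether another group at this place, such as a pyridyl ring, a thienyl ring or a simple methyl, would lower the number as well. They also leave open how much of the distance between the two cores belongs to the bromine on one of them and how much to the 4-chlorophenyl group on the other.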